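One Stereocentre Inverted in an Oxathiane Quaternary Ammonium Agonist

A few compounds are considered here, and "the series" means these few. Any claim that something is new, unique, unknown or untested is made for them only; others in the source may bear on it.

Two quaternary ammonium compounds built on a six-membered saturated ring have so far been measured in a functional assay on ileum for agonist activity at muscarinic acetylcholine receptor M3 (Cavia porcellus); on this read-out higher numbers stand for higher potency (the scale is a negative logarithm) and lower numbers for lower potency. Compound 1 , with the structure `C[C@H]1OCC[C@@H](C[N+](C)(C)C)O1`, gives 5.73 in this assay . Compound 2 , with the structure `C[C@H]1CSC[C@@H](C[N+](C)(C)C)O1`, gives 6.46 in this assay . Compound 2 thus stands higher of the two, and the gap to compound 1 is beyond the scatter of repeated measurements.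

The account now follows the step from compound 2 to compound 3 , whose structure is `C[C@H]1CSC[C@H](C[N+](C)(C)C)O1`. The two compounds have the same atoms and bonds and differ only in configuration as drawn: the two compounds have the same atoms and bonds and differ only in configuration as drawn: 1 of 2 stereo elements differ; a stereocentre at a saturated ring carbon is drawn R in compound 2 and S in compound 3, a stereocentre at a saturated ring carbon drawn R in compound 2 and S in compound 3.

Within the data shown here, no measured pair with a change of this kind is available for comparison. A downward step is expected in this assay , of the size a number 0.76 log units lower from compound 2 to compound 3 (beyond the scatter), since inversion at a ring stereocentre in a compact agonist of this type is not expected to leave potency untouched, though the direction is uncertain. Compound 3 is therefore estimated at 5.7, within a range from 4.9 to 6.6.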

Compound 3, negative logarithm of the half-maximal effective concentration: 5.21
Estimate against measurement, compound 3: 0.49 log units above; the range from low to high includes it.
By their numbers in this assay, from the lowest: compound 3; then compound 1; then compound 2.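

In this assay, the configuration at this saturated ring carbon proves to matter on its own: with nothing entering and nothing leaving, the change from R to S brings a number 1.25 log units lower from compound 2 to compound 3 (beyond the scatter). The pair of compound 1 and compound 2 offered no such view, as those two do not share the same atoms and bonds, and it said nothing about the effect of configuration at any position. Here, a step beyond the scatter can be traced to a single stereo element, with R the more potent form at this position in this pair, and nothing else in the structure can account for it: the fact that compounds 2 and 3 differ only in the configuration as drawn

The compounds shown leave open what inverting the second stereo element would do in this assay, either alone or together with the first. On these data alone, it also remains open whether R would still stand above S with a tertiary amine in place of the quaternary ammonium, or with an ethyl group or a longer chain on the shared core.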